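From compound 2 to compound 3: a new ring on the amide

This account rests on a few compounds, and the source may have more. Where it says the series, first, only, none or still open, it means among the compounds named here.

Going by the values given here, in a functional assay on MCF7 cells (Homo sapiens) for antiproliferative activity, read by MTT assay, with a stated time of 24 h (on this read-out higher numbers stand for weaker inhibition and lower numbers for stronger inhibition), compound 2 (`COC(=O)c1scc(-c2ccc(NC(=O)c3ccc(F)c(Cl)n3)cc2)c1OC`) gives 10300 nM, the higher of the two numbers measured so far, while compound 1 (`COC(=O)c1scc(-c2ccc(NC(=O)c3ccc4ccccc4c3)cc2)c1OC`) gives 90 nM. Compound 3 (`COC(=O)c1scc(-c2ccc(NC(=O)c3cccc(I)c3)cc2)c1OC`) differs from compound 2 in one place, on a carbonyl carbon whose other neighbour is an amide-type nitrogen: 3-iodophenyl in place of 6-chloro-5-fluoropyridin-2-yl on a carbonyl carbon. Among the compounds with values here, only one measured step bears on this change: a 110-fold higher number from compound 1 to compound 2 (2.06 log units; beyond the scatter), a large step at the same carbonyl carbon, with 6-chloro-5-fluoropyridin-2-yl in place of naphthalen-2-yl. The entering 3-iodophenyl has a ring of carbon only, as compound 1 does at that carbon, so part of that rise is expected to reverse in this assay, though one step cannot show how much. The expected change is a sizeable drop, an 8.6-fold lower number from compound 2 to compound 3 (0.93 log units; beyond the scatter). For compound 3 the estimated value is 1200 nM, within a range of 200 nM to 6000 nM.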

Compound 3, half-maximal inhibitory concentration: 12300 nM
The estimate for compound 3 lay 10-fold (1.01 log units) below the measured number; the whole stated range lies below it.
By their numbers in this assay, from the lowest: compound 1; then compounds 2 and 3 (each within the scatter of the next).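

In this assay, the step to 3-iodophenyl is a 1.2-fold higher number from compound 2 to compound 3 (0.08 log units; within the scatter), so on this carbonyl carbon a ring of carbon only does not by itself bring back a low number. Set against naphthalen-2-yl, the same group gives a 140-fold higher number from compound 1 to compound 3 (2.14 log units; beyond the scatter), which means that among these three compounds only the naphthalen-2-yl group of compound 1 gives a low number, while two quite different single rings give numbers within the scatter of each other. Nothing measured here explains the gap between naphthalen-2-yl and the other two groups.

Still open, on these data alone, is whether another large ring system, such as quinolin-2-yl or indol-5-yl, would keep a low number. Also open, as far as these compounds go, is whether a plain phenyl, or a phenyl bearing a methoxy group or an amine, would fall nearer to compound 1 or to compound 2 and compound 3.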